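Fluorophenyl Replacing Cyanophenyl on the Ring Nitrogen

The source may report more compounds than this note shows. Statements on the series, on what has been measured and on what is new or still open speak of the compounds shown alone.

Of the compounds shown here, three sharing one core have been measured in a functional assay on PC-12 cells (Rattus norvegicus) for cytotoxicity, read by MTT assay, with stated times of 2 h and 24 h, tested at 10 uM; on this read-out higher numbers stand for a stronger effect at the one concentration tested and lower numbers for a weaker effect. Compound 1 `Cc1ccc(-n2nc(-c3ccc(C(F)(F)F)cc3O)nc2-c2ccccc2O)cc1` gives 102%, compound 2 `CC(C)(C)c1ccc(-n2nc(-c3ccc(C(F)(F)F)cc3O)nc2-c2ccccc2O)cc1` gives 81.1%, and compound 3 `N#Cc1ccc(-n2nc(-c3ccc(C(F)(F)F)cc3O)nc2-c2ccccc2O)cc1` gives 98.9%. Compound 3 thus stands second highest of the three numbers, close to compound 1 and clearly apart from compound 2. The step with cyano in place of methyl on an aromatic carbon gave a number 3.1 percentage points lower from compound 1 to compound 3 (within the scatter), and the step with cyano in place of tert-butyl on an aromatic carbon gave a number 17.8 percentage points higher from compound 2 to compound 3 (beyond the scatter). Compound 4 `Oc1cc(C(F)(F)F)ccc1-c1nc(-c2ccccc2O)n(-c2cccc(F)c2)n1` differs from compound 3 as follows: 3-fluorophenyl in place of 4-cyanophenyl on an aromatic nitrogen. Among the compounds with values here, no measured step brings in fluorine, so the precedents bear only indirectly; among them the cyano-for-methyl exchange is the closer one, and it stayed within the scatter, whereas only tert-butyl produced a lower number. For compound 4 a step of a number 3.9 percentage points lower from compound 3 to compound 4 (within the scatter) is therefore expected, within the scatter. Compound 4 is estimated at 95%, between 78% and 110%.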

Compound 4, a percentage reported as activity, at one concentration (the size of the read-out at that concentration, not a potency): 98.3%
Compound 4: middle estimate off by 3.3 percentage points, on the low side; low and high end bracket the measured number.
By their numbers in this assay, from the lowest: compound 2; then compounds 4, 3 and 1 (each within the scatter of the next).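

In this assay, 3-fluorophenyl on the aromatic nitrogen brings in a new substituent and a new ring place at once, yet replacing 4-cyanophenyl gives a number 0.6 percentage points lower from compound 3 to compound 4 (within the scatter), and replacing 4-methylphenyl gives a number 3.7 percentage points lower from compound 1 to compound 4 (within the scatter). Replacing 4-(tert-butyl)phenyl gives a number 17.2 percentage points higher from compound 2 to compound 4 (beyond the scatter), so among these four compounds only compound 2 stands apart, and this position tolerates a substituent numbered 3 as well as one numbered 4. Nothing available explains why these numbers fall as they do.

The step changes the substituent and its ring place together, leaving their separate contributions unresolved; 4-fluorophenyl would be needed to divide them. From the compounds shown here alone, how an amine or a carboxylic acid on this phenyl ring, or a longer alkyl chain in place of tert-butyl, would read remains open.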